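The source may report more compounds than this note shows. Statements on the series, on what has been measured and on what is new or still open speak of the compounds shown alone.

Measured so far in an ADME assay on microsomes from liver (Homo sapiens) for metabolic stability, read by LC-MS, using NADPH, with a stated time of 10 min, tested at 10 uM; on this read-out lower numbers stand for a shorter-lived compound and higher numbers for a longer-lived compound:
- Compound 1 `Nc1ncnc2c1c(Oc1cc(C(F)(F)F)ccn1)nn2C1CCCC1`: 0.333 h
- Compound 2 `Nc1ncnc2c1c(Oc1cc(C(F)(F)F)ccn1)nn2[C@H]1CC[C@@H](CO)CC1`: 1.6 h
- Compound 3 `Nc1ncnc2c1c(Oc1cc(C(F)(F)F)ccn1)nn2[C@H]1CC[C@@H](N)CC1`: > 2.41 h (a limit, not a number)

Compound 3 stands at the limit of > 2.41 h in this assay, at which 1 of the 3 values shown sits. Its exact place in the series is therefore open.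

The next change leads to compound 4 `Nc1ncnc2c1c(Oc1cc(C(F)(F)F)ccn1)nn2CC1CC1`: cyclopropylmethyl in place of 4-aminocyclohexyl on an aromatic nitrogen, (cyclopropylmethyl in place of 4-aminocyclohexyl on an aromatic nitrogen).

For the measured compounds named here, two measured steps bear on this, both at the same nitrogen and both beyond the scatter: a 4.8-fold higher number from compound 1 to compound 2 (0.68 log units; beyond the scatter) and an at least 7.2-fold higher number from compound 1 to compound 3 (0.85 log units; beyond the scatter). The third, an at least 1.5-fold higher number from compound 2 to compound 3 (0.17 log units; that floor lies within the scatter), has a floor within the scatter and gives no direction. Like the cyclopentyl of compound 1, the entering group is a plain carbocycle-bearing substituent. The closest guide is thus compound 1 at 0.333 h, and the step of an at least 7.2-fold higher number from compound 1 to compound 3 (0.85 log units; beyond the scatter) is expected to run largely in reverse.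

In this assay, the expected change is an at least 6.0-fold lower number from compound 3 to compound 4 (0.77 log units; beyond the scatter), a fall beyond the scatter. Compound 4 is estimated at 0.4 h, with an expected range of 0.17 h to 1 h.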

Compound 4, half-life: 1.87 h
Compound 4: the middle estimate sits 4.7-fold (0.67 log units) below what was measured, and the stated range ends below it.
By their numbers in this assay, from the lowest: compound 1; then compounds 2 and 4 (each within the scatter of the next). At a limit, above all of these: compound 3.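

In this assay, the result separates a higher number at this nitrogen from the presence of a hydroxymethyl or amino group: the change from cyclopentyl to cyclopropylmethyl, which brings 0 hydrogen-bond donors and 0 hydrogen-bond acceptors, gives a 5.6-fold higher number from compound 1 to compound 4 (0.75 log units; beyond the scatter). Against 4-(hydroxymethyl)cyclohexyl, the same group gives a 1.2-fold higher number from compound 2 to compound 4 (0.07 log units; within the scatter) and so the two substituents cannot be told apart on this read-out. The remaining step of an at least 1.2-fold lower number from compound 3 to compound 4 (0.11 log units; that floor lies within the scatter) cannot be read because one end of it is a limit and not a number: the limit of > 2.41 h in this assay, at which 1 of the 4 values shown sits.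

The compounds shown do not say whether the step from compound 1 depends on the smaller ring or on the carbon link to the nitrogen. A cyclopropyl set directly on the nitrogen and an unsubstituted cyclohexyl would address these two points.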